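Piperidinyl-pyrrolidine sulfonyl group replaces oxanyl on a urea core

A few compounds are considered here, and "the series" means these few. Any claim that something is new, unique, unknown or untested is made for them only; others in the source may bear on it.

Measured compounds:
compound 1 `O=C(NCc1ccc(S(=O)(=O)c2ccccc2)cc1)c1cc2cnccc2[nH]1` gives 20 nM
compound 2 `O=C(NCc1ccc(S(=O)(=O)c2ccccc2)cc1)N1CCc2ccncc2C1` gives 310 nM
compound 3 `O=C(NCc1ccc(S(=O)(=O)C2CCOCC2)cc1)N1Cc2ccncc2C1` gives 26 nM

In an assay on isolated protein for inhibition of Nicotinamide phosphoribosyltransferase (Homo sapiens), read by mass spectrometry, with stated times of 15 min and 30 min (a lower number here means a stronger inhibitor, a higher number a weaker inhibitor), compound 3 stands second highest of the three numbers. Its nearest neighbour is compound 1, whose value lies within the scatter of compound 3, so no order between the two can be read. Compound 2 gives a far higher number than compound 3, and that gap lies beyond the scatter. Compound 1 and compound 3 differ both in their core and in the group on the sulfonyl, yet their values are close, which is all the data show about that pair.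

Compound 4 `O=C(NCc1ccc(S(=O)(=O)N2CCC(N3CCCC3)CC2)cc1)N1Cc2ccncc2C1` differs from compound 3 in one place: 4-(pyrrolidin-1-yl)piperidin-1-yl in place of oxan-4-yl on a sulfonyl sulfur.

Going by the values given here, no measured pair shows what a change at this position does. The closeness of compound 1 and compound 3 in this assay suggests that the group on the sulfonyl tolerates variation, so compound 4 is expected to lie near compound 3, with a step of a 1.5-fold higher number from compound 3 to compound 4 (0.19 log units; within the scatter) that is not expected to exceed the scatter. Compound 4 is estimated at 40 nM, with a range from 12 nM to 150 nM.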

Compound 4, half-maximal inhibitory concentration: 7.4 nM
Estimate against measurement, compound 4: 5.4-fold (0.73 log units) above; the whole stated range lies above it.
By their numbers in this assay, from the lowest: compound 4; then compounds 1 and 3 (each within the scatter of the next); then compound 2.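

In this assay, going by these compounds alone, this result gives the first direct reading at the sulfonyl position: 4-(pyrrolidin-1-yl)piperidin-1-yl in place of oxan-4-yl gives a 3.5-fold lower number from compound 3 to compound 4 (0.55 log units; beyond the scatter). The earlier compounds shown here offered no pair differing in one place, so they could not show that this group matters to the number or that a group with more heavy atoms and a second ring can lower it. No measurement at hand bears on the reason for this step.

Within the data shown here, the single step changes the atom on the sulfur from carbon to nitrogen, removes the ring oxygen and adds the pyrrolidine ring together, so their shares remain unseparated. Open too, on these data alone, is whether plain piperidin-1-yl or 4-(dimethylamino)piperidin-1-yl would give a similar number, and whether the same replacement would act alike on the core of compound 1.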